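Losing the Methyl Group on the Outer Aryl Ring

The compounds below may be only part of what the source reports. "The series", "measured", "known", "first", "only" and "open" are said of these compounds alone.

Of the compounds shown here, three sharing one core have been tested in a functional assay on HeLa cells (Homo sapiens) for antiproliferative activity, read by MTT assay, with a stated time of 72 h; a higher number here means a weaker inhibitor, a lower number a stronger inhibitor. Compound 1 `COc1cc(-n2ncnc2-c2cccc([N+](=O)[O-])c2)cc(OC)c1OC` gives > 10000 nM, which is a limit of the assay rather than a number. Compound 2 `COc1cc(-n2ncnc2-c2ccc(F)cc2)cc(OC)c1OC` gives > 10000 nM, again a limit. For the measured compounds named here, compound 3 `COc1cc(-n2ncnc2-c2ccc(C)cc2)cc(OC)c1OC` is the only compound with a measured number, 250 nM, and the only step between measured compounds that differ in one place is an at least 40-fold lower number from compound 2 to compound 3 (1.60 log units; beyond the scatter). Going by the values given here, that step ends at the one real number among the three, since two of the three values sit at the limit of > 10000 nM in this assay, at which 2 of the 3 values shown sit.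

Compound 4 `COc1cc(-n2ncnc2-c2ccccc2)cc(OC)c1OC` has not yet been measured. It differs from compound 3 by hydrogen in place of methyl on an aromatic carbon, the same change read one bond further out being 4-methylphenyl to phenyl. Among the compounds with values here, no measured step removes this group entirely; the one known step, exchanging fluoro for methyl, was large. With the methyl gone, a weaker result is expected, estimated as a step of an 8.0-fold higher number from compound 3 to compound 4 (0.90 log units; beyond the scatter). Compound 4 is expected to give 2000 nM, in a range from 300 nM to 10000 nM, with a real chance that only a limit is reported.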

Compound 4, half-maximal inhibitory concentration: > 10000 nM
Compound 4: no number, only a limit; the forecaster's own chance of this, stated with the estimate: 30%; at least 5.0-fold (0.69 log units) between middle value and limit.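

In this assay, for the compounds shown here, taking away only the methyl group gives an at least 40-fold higher number from compound 3 to compound 4 (1.60 log units; beyond the scatter), so a single carbon at this place, para to a large group, separates the one compound with a real number from a compound that reaches only a limit. The earlier step from fluoro to methyl could have meant that fluoro harms activity, but the result for hydrogen shows that compound 3 needs the methyl group itself, or something that acts like it. The steps from compound 1 and compound 2 to compound 4 cannot be read, and the series now sits mostly at one limit: the limit of > 10000 nM in this assay, at which 3 of the 4 values shown sit.

The compounds shown leave open whether anything else at this place can do the work of methyl, such as ethyl, a longer chain or chlorine. They also leave open whether methyl at another place on the outer ring would keep the activity.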